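The source may hold more compounds than are shown below. What is called first, only, known or untested is meant among the compounds shown, and "the series" means these compounds.

In a functional assay on KM12 cells (Homo sapiens) for inhibition, read by sulforhodamine B assay, with a stated time of 48 h (on this read-out lower numbers stand for higher toxicity in this test and higher numbers for lower toxicity in this test), compound 1 (`COc1cc(-c2cc(/C=C/C(=O)c3ccc(N)cc3)[nH]n2)cc(OC)c1OC`) gives 7270 nM and compound 2 (`COc1ccc(C(=O)/C=C/c2cc(-c3cc(OC)c(OC)c(OC)c3)n[nH]2)cc1`) gives 6020 nM. Among the measured compounds shown here, these are the only two numbers so far and they lie within the scatter of each other, so compound 1 holds no clear rank. Compound 3 (`COc1cc(-c2cc(/C=C/C(=O)c3ccc(F)c(F)c3)[nH]n2)cc(OC)c1OC`) carries 3,4-difluorophenyl in place of 4-aminophenyl on a carbonyl carbon. For the measured compounds named here, one measured step bears on this aromatic ring: a 1.2-fold lower number from compound 1 to compound 2 (0.08 log units; within the scatter), with methoxy in place of amino on an aromatic carbon, and it stays within the scatter. Going by the values given here, no measured compound carries fluorine, so this support is thin. No step beyond the scatter is therefore expected in this assay, and no direction is favoured. The expected step is a 1.2-fold lower number from compound 1 to compound 3 (0.08 log units; within the scatter). For compound 3 the estimated value is 6000 nM, with an expected range of 2500 nM to 14000 nM.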

Compound 3, concentration lethal to 50% of the cells: > 100000 nM
Compound 3 gave a limit, no number; the forecaster's own chance of this, stated with the estimate: 10%; at least 16-fold (1.22 log units) between middle value and limit.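

In this assay, the group on the carbonyl carbon can clearly move the read-out towards lower toxicity in this test: an at least 13-fold higher number from compound 1 to compound 3 (1.13 log units; beyond the scatter), and an at least 16-fold higher number from compound 2 to compound 3 (1.22 log units; beyond the scatter). The earlier change of amino to methoxy did not reveal this, since it gave only a 1.2-fold lower number from compound 1 to compound 2 (0.08 log units; within the scatter), leaving 4-aminophenyl and 4-methoxyphenyl within the scatter of each other while 3,4-difluorophenyl stands apart from both. The result for compound 3 is a limit, not a number, so both steps give only a minimum size: the limit of > 100000 nM in this assay, at which 1 of the 3 values shown sits.

As far as these compounds go, it remains open whether the two fluorines are both needed for this shift, or whether an unsubstituted phenyl, a 4-fluorophenyl or a 4-hydroxyphenyl group at this place would read like compound 1 or like compound 3. The data also leave open how far compound 3 actually lies from compound 1 and compound 2.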